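The compounds below may be only part of what the source reports. "The series", "measured", "known", "first", "only" and "open" are said of these compounds alone.

Compound 1 `CN(CCCn1c(=O)oc2ccccc21)Cc1ccccc1` is the unsubstituted parent of the series. In an assay on Jurkat cells for displacement of a labelled ligand from Sigma non-opioid intracellular receptor 1 (Homo sapiens), read by scintillation counting, with a stated time of 120 min (a lower number here means a stronger inhibitor, a higher number a weaker inhibitor), compound 1 gives only a limit, > 100 nM, so its position on the numbers is open beyond that limit (the limit of > 100 nM in this assay, at which 1 of the 2 values shown sits). For the measured compounds named here, compound 2 `CN(CCCn1c(=O)oc2cc(Br)ccc21)Cc1ccccc1` carries a bromo group on the aromatic ring of the core; in this assay compound 2 gives 0.9 nM, and the step of an at least 110-fold lower number from compound 1 to compound 2 (2.04 log units; beyond the scatter) is the single measured change so far.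

Compound 3 `CN(CCCn1c(=O)oc2ccc(Cl)cc21)Cc1ccccc1` is not yet measured in this assay. It differs from compound 1 by chloro in place of hydrogen on an aromatic carbon. Going by the values given here, the only step that bears on this change is the halogen step an at least 110-fold lower number from compound 1 to compound 2 (2.04 log units; beyond the scatter), which was large; a different halogen sits at a different place here, so the transfer is uncertain. Still, a substantial fall in the number is expected, an at least 20-fold lower number from compound 1 to compound 3 (1.30 log units; beyond the scatter), and compound 3 is estimated at 5 nM, within 0.5 nM to 50 nM.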

Compound 3, inhibition constant: 6.4 nM
The estimate for compound 3 lay 1.3-fold (0.11 log units) below the measured number, within the range that was stated.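

Compound 3 shows that a large step on this ring is not confined to bromo or to the carbon substituted in compound 2: chloro on an aromatic carbon, meta to a fused ring and para to a fused ring, gives an at least 15-fold lower number from compound 1 to compound 3 (1.19 log units; beyond the scatter) in this assay. With this step, both halogen-bearing compounds sit far below the parent, a statement that covers only these two substitutions. Compound 1 is held only as a limit, so this step gives a minimum size and no exact one: the limit of > 100 nM in this assay, at which 1 of the 3 values shown sits.

Compound 2 and compound 3 differ in both halogen and place, so the shown compounds cannot separate the effect of either alone. From the compounds shown here alone, whether fluoro, methyl or methoxy on this carbon would give a comparable step also remains open.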